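A few compounds are considered here, and "the series" means these few. Any claim that something is new, unique, unknown or untested is made for them only; others in the source may bear on it.

Of the compounds shown here, three sharing one core have been measured in a physicochemical assay for lipophilicity, using the shake flask method; on this read-out lower numbers stand for lower lipophilicity and higher numbers for higher lipophilicity. Compound 1 `C[C@H](Oc1ccc2ncc(/C=C/C(=O)O)cc2c1)c1c(Cl)ccc(F)c1Cl` gives 2.5, compound 2 `C[C@H](Oc1ccc2ncc(/C=C/C(=O)O)c(C#N)c2c1)c1c(Cl)ccc(F)c1Cl` gives 2.3 and compound 3 `C[C@H](Oc1ccc2ncc(/C=C/C(=O)O)c(-n3ccnc3)c2c1)c1c(Cl)ccc(F)c1Cl` gives 2. Compound 3 therefore sits under compound 1, with a number 0.50 log units lower from compound 1 to compound 3 (beyond the scatter), while a number 0.30 log units lower from compound 2 to compound 3 (within the scatter). Compound 4 `C[C@H](Oc1ccc2ncc(/C=C/C(=O)O)c(N(C)C)c2c1)c1c(Cl)ccc(F)c1Cl` changes one group of compound 3, dimethylamino in place of 1H-imidazol-1-yl, opposite the ring nitrogen: dimethylamino in place of 1H-imidazol-1-yl on an aromatic carbon. Among the measured compounds shown here, no measured step makes this exact swap. The closest guides are the changes at the same place, a number 0.20 log units lower from compound 1 to compound 2 (within the scatter) and a number 0.50 log units lower from compound 1 to compound 3 (beyond the scatter), and both are small. Only a small rise, within the scatter, is therefore expected, with a number 0.20 log units higher from compound 3 to compound 4 (within the scatter) as the estimated step. The estimate for compound 4 is 2.2, with an expected range from 1.6 to 2.8.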

Compound 4, distribution coefficient: 3.6
The estimate for compound 4 lay 1.40 log units below the measured number; the measured number lies above the stated range.
By their numbers in this assay, from the lowest: compounds 3, 2 and 1 (each within the scatter of the next, the first and the last beyond it); then compound 4.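

Dimethylamino on this aromatic carbon, opposite the ring nitrogen, shows that the position can also raise the number in this assay, with a number 1.10 log units higher from compound 1 to compound 4 (beyond the scatter). Neither cyano nor 1H-imidazol-1-yl gave such a rise, and replacing them gives a number 1.30 log units higher from compound 2 to compound 4 (beyond the scatter) and a number 1.60 log units higher from compound 3 to compound 4 (beyond the scatter). The choice of group at this one place can therefore shift the read-out widely.

Nothing measured here explains the rise. On these data alone, whether a plain amine, or diethylamino with its longer chains on the nitrogen, would raise the number as far remains open.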